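A bromo group added to compound 2

This account rests on a few compounds, and the source may have more. Where it says the series, first, only, none or still open, it means among the compounds named here.

In an ADME assay on L6 cells (Rattus norvegicus) for cytotoxicity, read by resazurin assay, with a stated time of 72 h (a lower number here means a stronger inhibitor, a higher number a weaker inhibitor), compound 1 (`Cc1ccc(C(O)(c2ccc(Cl)cc2)c2cccnc2)cc1`) gives 61000 nM. Compound 2 (`OC(c1ccc(Cl)cc1)(c1cccnc1)c1ccccc1F`) gives only a limit of the assay, > 100000 nM. For the measured compounds named here, the one measured step, an at least 1.6-fold higher number from compound 1 to compound 2 (0.21 log units; that floor lies within the scatter), concerns a different change, and its floor stays within the scatter, so it offers only a weak guide. Compound 3 (`OC(c1ccc(Cl)cc1)(c1cccnc1)c1ccc(Br)cc1F`) departs from compound 2 as follows: bromo in place of hydrogen on an aromatic carbon. Going by the values given here, with compound 1 at 61000 nM as the only firm number, a modest move to a lower number in this assay is expected. The expected step is an at least 1.6-fold lower number from compound 2 to compound 3 (0.22 log units; that floor lies within the scatter). Compound 3 is estimated at 60000 nM, within a range of 20000 nM to 120000 nM.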

Compound 3, half-maximal inhibitory concentration: 79200 nM
Compound 3: middle estimate off by 1.3-fold (0.12 log units), on the low side, and the stated range covers the measured number.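

In this assay, bromo on this aromatic carbon, meta to a fluoro group and para to a large group, gives an at least 1.2-fold lower number from compound 2 to compound 3 (0.10 log units; that floor lies within the scatter). Compound 3 provides a firm number at this position, but the true size of the step stays unknown because it starts from a limit of the assay: the limit of > 100000 nM in this assay, at which 1 of the 3 values shown sits.

The floor alone does not show a change beyond the scatter. From the compounds shown here alone, whether a methoxy group or an amine on the same carbon would shift the number in the same direction remains open, as does whether bromo would behave alike without the fluoro group.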